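The source may report more compounds than this note shows. Statements on the series, on what has been measured and on what is new or still open speak of the compounds shown alone.

Measured compounds:
compound 1, `CCCCCCCc1cccc2cncn12`, 3300 nM
compound 2, `O=C(O)CCCCc1ccn2cncc2c1`, 4700 nM

In an assay for inhibition of Thromboxane-A synthase (Homo sapiens) (a higher number here means a weaker inhibitor, a lower number a stronger inhibitor), compound 1 gives 3300 nM, the lower of the two numbers; compound 2 gives 4700 nM, which lies within the scatter of that result, so the two cannot be ranked against each other. Compound 3, `C/C(=C\CCCCCc1cccc2cncn12)C(=O)O`, has not yet been tested in this assay. It differs from compound 1 in one respect: 2-carboxyprop-1-en-1-yl in place of ethyl on a saturated chain carbon, five bonds along the chain from an aromatic carbon. The change introduces an acid on the chain while the shared core is kept. Among the measured compounds shown here, nothing among the measured pairs shows what such a change does; compound 2 carries an acid on a chain as well, yet its value sits beside that of compound 1. The step from compound 1 to compound 3 is expected to be a moderate one toward a lower number, a 3.7-fold lower number from compound 1 to compound 3 (0.56 log units; beyond the scatter), though the data leave room for no change beyond the scatter. Compound 3 is therefore estimated at 900 nM, within a range of 150 nM to 4500 nM.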

Compound 3, half-maximal inhibitory concentration: 19 nM
Beside the measured number, compound 3's estimate is 47-fold (1.68 log units) above it; the measured number lies below the stated range.
By their numbers in this assay, from the lowest: compound 3; then compounds 1 and 2 (each within the scatter of the next).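

In this assay the exchange of ethyl for 2-carboxyprop-1-en-1-yl on a saturated chain carbon, five bonds along the chain from an aromatic carbon, brings a 170-fold lower number from compound 1 to compound 3 (2.24 log units; beyond the scatter) and gives the first step that can be read among these compounds. With the shared core kept, it shows that the number responds strongly to what is carried at this place on the chain, which the two earlier values could not show. Nothing at hand accounts for the size of this step. The compounds shown leave open which part of the entering group carries the step, since it is not separated from a saturated chain bearing a carboxylic acid or from the methyl ester of compound 3. Also open, going by these compounds, is whether a longer or shorter chain bearing the same carboxylic acid would give a similar number.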